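Dichloro core variant in the benzyl chloride series

The source may report more compounds than this note shows. Statements on the series, on what has been measured and on what is new or still open speak of the compounds shown alone.

Measured so far:
compound 1 `ClCc1ccc(Cn2cnc3c(Cl)ncnc32)cc1` — 3540 nM
compound 2 `ClCc1ccccc1Cn1cnc2c(Cl)ncnc21` — 1820 nM

Compound 1 carries the higher of the two numbers in a functional assay on NCI-H522 cells (Homo sapiens) for cytotoxicity, read by sulforhodamine B assay, with a stated time of 48 h (on this read-out higher numbers stand for weaker inhibition of growth and lower numbers for stronger inhibition of growth), but its gap to compound 2 lies within the scatter, so the two are not separated. Compound 3 `ClCc1ccc(Cn2cnc3c(Cl)nc(Cl)nc32)cc1` differs from compound 1 by chloro in place of hydrogen on an aromatic carbon, on the shared core, between two ring nitrogen atoms. For the measured compounds named here, no measured pair shows this change, so no step size is known. A small move is expected, a 1.4-fold lower number from compound 1 to compound 3 (0.15 log units; within the scatter), not clearly beyond the scatter in either direction. Compound 3 is estimated at 2500 nM, within 800 nM to 8000 nM.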

Compound 3, concentration for 50% growth inhibition: 22400 nM
Estimate against measurement, compound 3: 9.0-fold (0.95 log units) below; measured number above the stated range.
By their numbers in this assay, from the lowest: compounds 2 and 1 (each within the scatter of the next); then compound 3.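

In this assay, chloro in place of hydrogen on an aromatic carbon of the shared core, between two ring nitrogen atoms, gives a 6.3-fold higher number from compound 1 to compound 3 (0.80 log units; beyond the scatter) and so a step beyond the scatter towards weaker inhibition of growth. This position is thus sensitive to substitution, which compound 1 and compound 2 could not show, as both carry hydrogen there. Nothing at hand explains the step.

On these data alone, whether any group on this carbon weakens inhibition of growth, or chloro in particular, stays open; an amine or a methoxy group there would help to tell. Also open, as far as these compounds go, is whether chloro at this place has the same effect on compound 2.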